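A few compounds are considered here, and "the series" means these few. Any claim that something is new, unique, unknown or untested is made for them only; others in the source may bear on it.

Measured compounds:
- compound 1 `CC1=NN(C(=O)CN2CCCCC2)C(c2ccccc2O)C1`: 5890 nM
- compound 2 `Cc1ccc(C(=O)N2N=C(c3cc4ccccc4oc3=O)CC2c2ccccc2)cc1`: 13200 nM

In a functional assay on PC-3 cells (Homo sapiens) for cytotoxicity, read by MTT assay, with a stated time of 48 h (on this read-out higher numbers stand for weaker inhibition and lower numbers for stronger inhibition), compound 1 gives 5890 nM, while compound 2 gives 13200 nM. Compound 2 thus stands at the highest number of the two; the gap to compound 1 lies beyond the scatter, so compound 2 reads as the weaker of the pair. Among the measured compounds shown here, no step between measured compounds that differ in one place is available, so the effect of any single change rests on inference alone.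

Compound 3 `CC(C)(C)NCC(=O)N1N=C(c2cc3ccccc3oc2=O)CC1c1ccccc1` is not yet measured. It differs from compound 2 as follows: ((tert-butyl)amino)methyl in place of 4-methylphenyl on a carbonyl carbon. Compound 1 also carries an aminomethyl carbonyl on its ring nitrogen and gives 5890 nM, which is the only hint that such a group is tolerated. The step from compound 2 to compound 3 is expected to be modest, toward a lower number, at a 1.7-fold lower number from compound 2 to compound 3 (0.22 log units; within the scatter). For compound 3 the estimate is 8000 nM, with a range of 3000 nM to 25000 nM.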

Compound 3, half-maximal inhibitory concentration: 16400 nM
Estimate against measurement, compound 3: 2.1-fold (0.31 log units) below; measured number inside the range.
By their numbers in this assay, from the lowest: compound 1; then compounds 2 and 3 (each within the scatter of the next).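

In this assay, ((tert-butyl)amino)methyl in place of 4-methylphenyl on a carbonyl carbon gives a 1.2-fold higher number from compound 2 to compound 3 (0.09 log units; within the scatter) and so separates neither compound from the other. Among the compounds shown here, this is the first reading of a single change. On the shared core, this place accepts either one six-membered aromatic ring of carbon only or an open chain with no ring and a nitrogen, with no change beyond the scatter, and no supporting measurement offers an explanation for this.

Going by these compounds, whether any group on this carbonyl carbon can move the number beyond the scatter stays open, for example a morpholine ring reached through a methylene or a carboxylic acid on a longer chain. On these data alone, how far this single result holds for other substituents on the shared core also stays open.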